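This account rests on a few compounds, and the source may have more. Where it says the series, first, only, none or still open, it means among the compounds named here.

Compound 1 `O=C(O)CCC/C=C1\C[C@H]2C[C@@H](O)[C@H](/C=N/OCc3ccc(F)cc3)[C@H]2C1`: 1500 nM
Compound 2 `O=C(O)CCC/C=C1\C[C@H]2C[C@@H](O)[C@H](/C=N\OC(c3ccccc3)c3ccccc3)[C@H]2C1`: 1000 nM

Only these two compounds have been measured so far, both in a functional assay with Homo sapiens as the target; on this read-out lower numbers stand for stronger inhibition and higher numbers for weaker inhibition. There, compound 1 gives 1500 nM and compound 2 gives 1000 nM, so the two stand within the usual scatter of each other. The next compound to be measured in this assay is compound 3 `O=C(O)CCC/C=C1\C[C@H]2C[C@@H](O)[C@H](/C=N/OCc3ccccc3)[C@H]2C1`, which keeps the core of compound 1 and changes it in a single place. The difference is hydrogen in place of fluoro on an aromatic carbon, turning the 4-fluorobenzyl group into a benzyl group. Among the measured compounds shown here, no measured pair of compounds differs in one place only, so the data give no direct guide to the size of this change. With nothing to indicate a larger shift, no step beyond the scatter is expected, and the starting point remains compound 1 at 1500 nM. The estimate corresponds to no change at the digits printed from compound 1 to compound 3 (within the scatter). For compound 3 the expected value is 1500 nM, with an estimated range from 500 nM to 4500 nM.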

Compound 3, half-maximal inhibitory concentration: 2000 nM
Estimate against measurement, compound 3: 1.3-fold (0.12 log units) below, and the stated range covers the measured number.
By their numbers in this assay, from the lowest: compounds 2, 1 and 3 (each within the scatter of the next).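

In this assay, among the compounds shown here, this pair gives the first reading of a single change: hydrogen in place of fluoro, turning the 4-fluorobenzyl group into a benzyl group, gives a 1.3-fold higher number from compound 1 to compound 3 (0.12 log units; within the scatter). At this aromatic carbon, para to a large group, fluoro and hydrogen therefore cannot be told apart on this read-out, and the fluoro is not needed for compound 3 to show inhibition in the same range as compound 1.

Going by these compounds, this single pair covers only fluoro and hydrogen, so it remains open whether a larger or different group at this place, such as chloro, methoxy or an amine, would also stay within the scatter or would produce a clear step. The compounds shown also leave open whether the benzyl group tolerates changes elsewhere on its ring, and whether replacing the carboxylic acid with a group such as a tetrazole or an amide would matter more than this exchange does. No measurement is available that bears on this result or accounts for it.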